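Working notes: aryl change from compound 2 to compound 4

A few compounds are considered here, and "the series" means these few. Any claim that something is new, unique, unknown or untested is made for them only; others in the source may bear on it.

In a functional assay on HCT-116 cells (Homo sapiens) for inhibition, read by MTT assay, with a stated time of 2 days (on this read-out higher numbers stand for weaker inhibition of growth and lower numbers for stronger inhibition of growth), compound 2 `Nc1ccccc1NC(=O)CCCNCC(=O)Nc1ccc(Br)cc1` gives 7700 nM and sits within the scatter of compound 1 `Nc1ccccc1NC(=O)CCCNCC(=O)Nc1ccc(Cl)cc1` at 5500 nM in the same read-out. Compound 3 `Nc1ccccc1NC(=O)c1ccc(NCC(=O)Nc2ccc([N+](=O)[O-])cc2)cc1`, on a different core, gives a clearly lower 600 nM here. Compound 4 `Nc1ccccc1NC(=O)CCCNCC(=O)Nc1cc(Cl)ccc1Cl` differs from compound 2 thus: 2,5-dichlorophenyl in place of 4-bromophenyl on an amide-type nitrogen in the words of the change, 2,5-dichlorophenyl in place of 4-bromophenyl on an amide-type nitrogen. For the measured compounds named here, the only measured step on this group is a 1.4-fold higher number from compound 1 to compound 2 (0.15 log units; within the scatter) and it covers a single halogen swap, within the scatter. Going by the values given here, no measured compound carries the 2,5-dichlorophenyl group. In this assay the expected step is a 1.3-fold lower number from compound 2 to compound 4 (0.11 log units; within the scatter) and so no shift beyond the scatter in either direction. Compound 4 is estimated at 6000 nM with an expected range from 2500 nM to 14000 nM overall.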

Compound 4, concentration for 50% growth inhibition: 31000 nM
Beside the measured number, compound 4's estimate is 5.2-fold (0.71 log units) below it, outside the stated range (above it).
By their numbers in this assay, from the lowest: compound 3; then compounds 1 and 2 (each within the scatter of the next); then compound 4.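

In this assay, the aryl group on the amide-type nitrogen now makes a difference beyond the scatter: 2,5-dichlorophenyl in place of 4-bromophenyl gives a 4.0-fold higher number from compound 2 to compound 4 (0.60 log units; beyond the scatter), and in place of 4-chlorophenyl gives a 5.6-fold higher number from compound 1 to compound 4 (0.75 log units; beyond the scatter). The single halogen swap had shown no such shift, so this position is not indifferent to the aryl group, and this change goes toward weaker inhibition of growth. Nothing available explains the size or direction of these steps.

The compounds shown do not separate the contributions of the two chlorines in 2,5-dichlorophenyl. On these data alone, how an unsubstituted phenyl or a methoxyphenyl on this nitrogen would read also stays open.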